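The source may report more compounds than this note shows. Statements on the series, on what has been measured and on what is new or still open speak of the compounds shown alone.

Compound 1 `O=[N+]([O-])c1ccc(/N=N/N2CCCC2)cc1`: >= 100000 nM
Compound 2 `Brc1cccc(/N=N/N2CCCCC2)c1`: > 100000 nM
Compound 3 `Brc1ccc(/N=N/N2CCCC2)cc1`: > 100000 nM

Of the compounds shown here, three have been measured in an ADME assay on MT4 cells (Homo sapiens) for cytotoxicity, read by MTT assay, with a stated time of 96 h; on this read-out lower numbers stand for higher toxicity in this test and higher numbers for lower toxicity in this test. Compound 1 gives >= 100000 nM in this assay, which is a limit of the assay rather than a number. Compound 3 gives > 100000 nM in this assay, again a limit. Compound 2 gives > 100000 nM in this assay, also a limit. The change from compound 3 to compound 1 is nitro in place of bromo on an aromatic carbon, and the step that the two limits leave unreadable from compound 3 to compound 1 cannot be read because the limit of > 100000 nM in this assay, at which 2 of the 3 values shown sit, and the limit of >= 100000 nM in this assay, at which 1 of the 3 values shown sits, are where its two values sit. The difference between the core of compound 2 and the core of compound 3 is not broken down here.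

Compound 4 `O=[N+]([O-])c1cccc(/N=N/N2CCCCC2)c1` has not yet been measured. The change from compound 2 to compound 4 is nitro in place of bromo on an aromatic carbon. It is the same kind of change as from compound 3 to compound 1, but the surroundings differ: in compound 4 the nitro sits meta to a group of 8 heavy atoms, whereas in compound 1 it sits para to a group of 7 heavy atoms.

The step from compound 2 to compound 4 is expected to be a number no higher from compound 2 to compound 4 (the limit leaves the size open). This expectation rests on compound 2, whose value > 100000 nM is a limit. It also rests on compound 1, whose value >= 100000 nM is a limit. Compound 4 is therefore estimated at 100000 nM, most likely between 50000 nM and 200000 nM, and the assay is expected to report only a limit again.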

Compound 4, half-maximal cytotoxic concentration: > 100000 nM
Compound 4 was reported as a limit (the forecaster's own chance of this, stated with the estimate: 85%); the middle value lies on the limit itself.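

In this assay compound 4 gives > 100000 nM, which is a limit of the assay rather than a number. Compound 2 is also reported only as a limit, so no new step can be read between compound 2 and compound 4. The compounds shown leave open how large the half-maximal cytotoxic concentration of each one is, and whether nitro in place of bromo on an aromatic carbon changes it at all: the limit of > 100000 nM in this assay, at which 3 of the 4 values shown sit.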